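Chloro in Place of Trifluoromethyl: an Expected Step

The source may hold more compounds than are shown below. What is called first, only, known or untested is meant among the compounds shown, and "the series" means these compounds.

Measured so far:
compound 1, `CCC(C(=O)N1CCN(c2cccc(OC)c2)CC1)N1C(=O)CCC1=O`: 0%
compound 2, `CCC(C(=O)N1CCN(c2ccc(F)cc2)CC1)N1C(=O)CCC1=O`: 0%
compound 3, `CCC(C(=O)N1CCN(c2cccc(C(F)(F)F)c2)CC1)N1C(=O)CCC1=O`: 50%

In a functional assay on the whole organism (strain Swiss) with Mus musculus as the target, in the maximal electroshock model, with a stated time of 2 h, at a dose of 300 mg/kg by the intraperitoneal route (on this read-out lower numbers stand for a weaker effect and higher numbers for a stronger effect at the one dose given), compound 3 holds the highest of the three numbers. Its lead over compound 1 is the step of a number 50 percentage points higher from compound 1 to compound 3 (beyond the scatter), and compound 2 lies as far beneath it, while no change at the digits printed from compound 1 to compound 2 (within the scatter).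

Compound 4 is `CCC(C(=O)N1CCN(c2cccc(Cl)c2)CC1)N1C(=O)CCC1=O`. The change is chloro in place of trifluoromethyl on an aromatic carbon: trifluoromethyl leaves and chloro enters. Going by the values given here, no measured step swaps these two groups. Among the compounds with values here, the only step at this position, a number 50 percentage points higher from compound 1 to compound 3 (beyond the scatter), was large, so the group sitting there matters. As far as these compounds go, for compound 4 a moderate decrease is expected, a number 25 percentage points lower from compound 3 to compound 4 (beyond the scatter), since chloro is untested here. Compound 4 is estimated at 25%, between 0% and 55%.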

Compound 4, a percentage reported as activity, at one dose (the size of the read-out at that dose, not a potency): 25%
Estimate against measurement, compound 4: no gap at the digits printed, and the stated range covers the measured number.
By their numbers in this assay, from the lowest: compounds 1 and 2 (each within the scatter of the next); then compound 4; then compound 3.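

Chloro in this spot keeps part of the effect of trifluoromethyl, with a number 25 percentage points lower from compound 3 to compound 4 (beyond the scatter), so the effect at this position does not depend on trifluoromethyl alone. Against methoxy the same group gives a number 25 percentage points higher from compound 1 to compound 4 (beyond the scatter), and against the 4-fluorophenyl compound it gives a number 25 percentage points higher from compound 2 to compound 4 (beyond the scatter), which places chloro midway among these groups. Nothing measured here explains why these groups differ.

Still open, as far as these compounds go, is where a bromo, methyl or nitrile group on this same aromatic carbon would fall, and whether any could match or pass trifluoromethyl.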